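Piperidine hydroxamates: benzyl to phenyl on the sulfonyl

A few compounds are considered here, and "the series" means these few. Any claim that something is new, unique, unknown or untested is made for them only; others in the source may bear on it.

Compound 1 `CC(C)c1ccc(S(=O)(=O)N2CCC(CCCC(=O)NO)CC2)cc1` carries no result in a functional assay on HCT-116 cells (Homo sapiens) for inhibition, read by resazurin assay, with a stated time of 5 days (on this read-out lower numbers stand for stronger inhibition of growth and higher numbers for weaker inhibition of growth), its entry reading "not determined" (no result reported). Among the measured compounds shown here, compound 2 `O=C(CCCC1CCN(S(=O)(=O)Cc2ccccc2)CC1)NO` gives 3200 nM in this assay and is the only compound of the series with a number, so no step between measured compounds can be drawn. Compound 3 `O=C(CCCC1CCN(S(=O)(=O)c2ccccc2)CC1)NO` differs from it by phenyl in place of benzyl on a sulfonyl sulfur. With nothing measured to lean on, the expected step of a 1.1-fold lower number from compound 2 to compound 3 (0.06 log units; within the scatter) is none beyond the usual scatter. Compound 3 is estimated at 2800 nM in this assay, with a range from 900 nM to 9000 nM.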

Compound 3, concentration for 50% growth inhibition: 2700 nM
The estimate for compound 3 lay 1.0-fold (0.02 log units) above the measured number; low and high end bracket the measured number.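

Phenyl in place of benzyl on a sulfonyl sulfur gives a 1.2-fold lower number from compound 2 to compound 3 (0.07 log units; within the scatter) in this assay. Among the compounds shown here, this is the first readable step, and it shows that the two groups cannot be told apart on this read-out at this position. No supporting data bear on this result.

The step involving compound 1 cannot be read, as its entry carries no number. Going by these compounds, whether a phenethyl group on the sulfonyl sulfur, or an amine or carboxylic acid on the phenyl ring, would give a step beyond the scatter remains open.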